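This account rests on a few compounds, and the source may have more. Where it says the series, first, only, none or still open, it means among the compounds named here.

Series notes. Compound 1 `COc1ccc(C2=NNC(c3c(Cl)cccc3Cl)C2)cc1OC` and compound 2 `COc1ccc(C2=NN(C(=O)C(C)Br)C(c3ccco3)C2)cc1OC` have been run in a functional assay on the whole organism (strain albino) for inhibition, with Rattus norvegicus as the target, read by paw edema, with stated times of 30 min and 1 h, at a dose of 100 mg/kg by the oral route; on this read-out lower numbers stand for less inhibition and higher numbers for more inhibition at the one dose given (going by the name of the read-out). Compound 1 gives 26% in this assay. Compound 2 gives 22%, the lower of the two numbers, but the gap to compound 1 lies within the scatter, so no order between them is read. Compound 3 `COc1ccc(C2=NN(C(=O)C(C)Br)C(c3c(Cl)cccc3Cl)C2)cc1OC` differs from compound 2 in one place: 2,6-dichlorophenyl in place of furan-2-yl on a saturated ring carbon. Compound 1 already carries the 2,6-dichlorophenyl group and in this assay gives 26%, within the scatter of compound 2, so no step beyond the scatter is expected. The expected step is a number 3 percentage points higher from compound 2 to compound 3 (within the scatter). Compound 3 is estimated at 25%, between 12% and 38%.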

Compound 3, a percentage reported as inhibition, in the whole organism at one dose (the size of the read-out at that dose, not a potency): 51%
Compound 3: middle estimate off by 26 percentage points, on the low side; measured number above the stated range.
By their numbers in this assay, from the lowest: compounds 2 and 1 (each within the scatter of the next); then compound 3.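

In this assay, the saturated ring carbon responds to the choice of aryl group when the ring nitrogen carries (1-bromoethyl)carbonyl: the step of a number 29 percentage points higher from compound 2 to compound 3 (beyond the scatter) comes with 2,6-dichlorophenyl in place of furan-2-yl. With 2,6-dichlorophenyl held in place, the ring nitrogen also matters: the step of a number 25 percentage points higher from compound 1 to compound 3 (beyond the scatter) comes with (1-bromoethyl)carbonyl in place of hydrogen. Nothing available bears on the reason for either step. Open, from the compounds shown here alone, is whether an acetyl group on the ring nitrogen, lacking the bromine, keeps the second step. Also open, going by these compounds, is whether a phenyl ring with a single chlorine keeps the first.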